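Chloro for Nitro on a Quinazoline-Free Named Core

The source may hold more compounds than are shown below. What is called first, only, known or untested is meant among the compounds shown, and "the series" means these compounds.

Compound 1, `COc1cc(Nc2ncnc3c(NC(=O)Nc4ccc([N+](=O)[O-])cc4)cccc23)cc(OC)c1`, was tested in a functional assay on RT-112 cells (Homo sapiens) for antiproliferative activity, read by MTT assay, with a stated time of 72 h; on this read-out higher numbers stand for weaker inhibition of growth and lower numbers for stronger inhibition of growth. In this assay compound 1 reaches only the assay limit of > 20000 nM, so no number is known for it. Compound 2, `COc1cc(Nc2ncnc3c(NC(=O)Nc4ccc(C(F)(F)F)cc4[N+](=O)[O-])cccc23)cc(OC)c1`, carries a trifluoromethyl group as well as the nitro group on its terminal aromatic ring. In this assay compound 2 likewise gives only the limit of > 20000 nM, not a measured value. Going by the values given here, compound 2 therefore stands nowhere on a scale of numbers: both values shown in this assay sit at the same limit, as recorded in the limit of > 20000 nM in this assay, at which 2 of the 2 values shown sit, and no step between measured compounds can be stated.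

Compound 3, `COc1cc(Nc2ncnc3c(NC(=O)Nc4ccc(C(F)(F)F)cc4Cl)cccc23)cc(OC)c1`, differs from compound 2 in one place: chloro in place of nitro on an aromatic carbon. Among the compounds with values here, with no measured step to lean on, the account can only say that the change is expected to move the value by a step that the limit leaves unreadable from compound 2 to compound 3, that is, by nothing that can be told from the limit. Compound 3 is accordingly estimated to give about 25000 nM in this assay, within a range from 8000 nM to 70000 nM, and most likely to be reported again only as a limit.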

Compound 3, concentration for 50% growth inhibition: 1080 nM
Compound 3: middle estimate off by 23-fold (1.36 log units), on the high side, and the stated range ends above it.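

In this assay, chloro in place of nitro on an aromatic carbon, ortho to a large group and meta to a trifluoromethyl group, brings an at least 18-fold lower number from compound 2 to compound 3 (1.26 log units; beyond the scatter), and this single change turns a compound without a readable value into one with a measured value. The 2-chloro-4-(trifluoromethyl)phenyl in place of 4-nitrophenyl on an amide-type nitrogen brings an at least 18-fold lower number from compound 1 to compound 3 (1.26 log units; beyond the scatter), so with the shared core unchanged, the group on that nitrogen decides whether growth inhibition can be read at all; the trifluoromethyl group of compound 2 did not achieve this while nitro remained. Both steps are minimum sizes, and how much larger they really are cannot be read: the limit of > 20000 nM in this assay, at which 2 of the 3 values shown sit.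

The compounds shown leave open whether an amine, a methoxy group or plain hydrogen on that carbon would serve as chloro does, so the step cannot yet be assigned to the arrival of chloro rather than the departure of nitro. They also leave open whether trifluoromethyl is needed alongside chloro, or whether a methyl group or fluoro could stand in its place.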